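Swapping the Aryl Ether Cap: Cytotoxicity Outlook for Compound 3

This account rests on a few compounds, and the source may have more. Where it says the series, first, only, none or still open, it means among the compounds named here.

For the measured compounds named here, compound 2 `COc1ccc(Oc2ccc3c(NCCCNCc4cccc(OC)c4O)ccnc3c2)cc1` gives the higher of the two numbers so far in an ADME assay on HepG2 cells (Homo sapiens) for cytotoxicity, read by luminescence, CellTiter-Glo and ATP content, with a stated time of 72 h (a higher number here means that more compound is needed for the effect, a lower number that less compound is needed), at 5500 nM, while compound 1 `COc1cccc(CNCCCNc2ccnc3cc(C4CCCCC4)ccc23)c1O` gives 1080 nM; the only step known, a 5.1-fold higher number from compound 1 to compound 2 (0.71 log units; beyond the scatter), is modest. Compound 3 `COc1cccc(CNCCCNc2ccnc3cc(Oc4cccc(N(C)C)c4)ccc23)c1O` differs from compound 2 by 3-(dimethylamino)phenyl in place of 4-methoxyphenyl on an oxygen on an aromatic ring. Going by the values given here, no measured step touches this exact change, since the one known step replaces the whole aryl ether rather than a substituent on its outer ring. The step of a 1.2-fold lower number from compound 2 to compound 3 (0.09 log units; within the scatter) is therefore expected to stay within the scatter. Compound 3 is estimated at 4500 nM, with a range from 1800 nM to 12000 nM.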

Compound 3, half-maximal effective concentration in the HepG2 assay: 7300 nM
Estimate against measurement, compound 3: 1.6-fold (0.21 log units) below; low and high end bracket the measured number.
By their numbers in the HepG2 assay, from the lowest: compound 1; then compounds 2 and 3 (each within the scatter of the next).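

In the HepG2 assay the 3-(dimethylamino)phenyl in place of 4-methoxyphenyl on this oxygen gives a 1.3-fold higher number from compound 2 to compound 3 (0.12 log units; within the scatter), so this change to the outer ring leaves compound 3 at 7300 nM unresolved from compound 2 at 5500 nM. In a physicochemical assay for solubility, with a stated time of 18 h, at pH 7.4 (on this read-out higher numbers stand for higher solubility and lower numbers for lower solubility), the same change gives no change at the digits printed from compound 2 to compound 3 (within the scatter) as well, with compound 2 at 14500 nM and compound 3 at 14500 nM. Back in the HepG2 assay the 3-(dimethylamino)phenoxy in place of cyclohexyl gives a 6.8-fold higher number from compound 1 to compound 3 (0.83 log units; beyond the scatter) and so matches the direction of the earlier step. Nothing measured here explains these results. From the compounds shown here alone, whether a carboxylic acid on the outer ring would also leave both numbers in place remains open.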